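Hydroxyl Out, Nitro In on the Pendant Phenyl

The source may hold more compounds than are shown below. What is called first, only, known or untested is meant among the compounds shown, and "the series" means these compounds.

Compound 1 `C/C(=C\CC/C(C)=C/CC[C@@H]1[C@@]2(C)CCC(=O)C(C)(C)[C@H]2CC[C@@]1(C)O)CC/C=C(\C)C(=O)OCc1cn(-c2ccccc2Cl)nn1` gives in a functional assay on A549 cells (Homo sapiens) for antiproliferative activity, read by MTT assay, with a stated time of 48 h (on this read-out higher numbers stand for weaker inhibition and lower numbers for stronger inhibition), only a limit, > 150000 nM.
Compound 2 `C/C(=C\CC/C(C)=C/CC[C@@H]1[C@@]2(C)CCC(=O)C(C)(C)[C@H]2CC[C@@]1(C)O)CC/C=C(\C)C(=O)OCc1cn(-c2cccc(O)c2)nn1` gives in this assay 42800 nM.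
Compound 3 `C/C(=C\CC/C(C)=C/CC[C@@H]1[C@@]2(C)CCC(=O)C(C)(C)[C@H]2CC[C@@]1(C)O)CC/C=C(\C)C(=O)OCc1cn(-c2ccccc2C(F)(F)F)nn1` gives in this assay only a limit, > 150000 nM.

Going by the values given here, compound 2 thus holds the only actual number among the three; the other two sit at a limit (the limit of > 150000 nM in this assay, at which 2 of the 3 values shown sit). Compound 4 `C/C(=C\CC/C(C)=C/CC[C@@H]1[C@@]2(C)CCC(=O)C(C)(C)[C@H]2CC[C@@]1(C)O)CC/C=C(\C)C(=O)OCc1cn(-c2ccc([N+](=O)[O-])cc2)nn1` differs from compound 2 in one place: 4-nitrophenyl in place of 3-hydroxyphenyl on an aromatic nitrogen. Among the compounds with values here, two measured steps bear on this exchange: an at least 3.5-fold lower number from compound 1 to compound 2 (0.54 log units; beyond the scatter) and an at least 3.5-fold higher number from compound 2 to compound 3 (0.54 log units; beyond the scatter). In both, the phenyl group lacking the hydroxyl gave only a limit. Removing the hydroxyl again in compound 4 is therefore expected to raise the number, and the estimate may well end up at a limit: a 2.8-fold higher number from compound 2 to compound 4 (0.45 log units; beyond the scatter). For compound 4 the expected value is 120000 nM, within a range from 40000 nM to 300000 nM.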

Compound 4, half-maximal inhibitory concentration: > 150000 nM
Compound 4 gave a limit, no number (the forecaster's own chance of this, stated with the estimate: 55%); middle value at least 1.2-fold (0.09 log units) away from the limit.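

In this assay, 4-nitrophenyl in place of 3-hydroxyphenyl gives an at least 3.5-fold higher number from compound 2 to compound 4 (0.54 log units; beyond the scatter), so the loss seen with 2-chlorophenyl and 2-(trifluoromethyl)phenyl also appears with a group of a different name and pattern. Compound 4 gives a limit, not a number, and joins compounds 1 and 3 there: the limit of > 150000 nM in this assay, at which 3 of the 4 values shown sit. The steps among compounds 1, 3 and 4 cannot be read, so these three cannot be ranked. Still open, on these data alone, is whether the number depends on the hydroxyl itself or on where it sits; 4-hydroxyphenyl or 3-aminophenyl could separate these two readings.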